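Working notes: 2-fluorophenyl to 2-isopropylphenyl

The compounds below may be only part of what the source reports. "The series", "measured", "known", "first", "only" and "open" are said of these compounds alone.

Of the compounds shown here, two have been measured so far in a physicochemical assay for lipophilicity, read by HPLC, in phosphate buffer, measured as octanol-water partition, at pH 7.4, tested at 100 uM; a higher number here means a more lipophilic compound, a lower number a more polar compound. Compound 1 (`CCOc1cc(C)c(-c2cccc(CNc3ccc(OCC(=O)O)c(F)c3)c2)c(C)c1`) gives 3.04 and compound 2 (`O=C(O)COc1ccc(NCc2cccc(-c3ccccc3F)c2)cc1F`) gives 2.36 on the same scale. Compound 2 therefore holds the lower of the two numbers, and its gap to compound 1 lies beyond the scatter of repeated measurements.

Going by the values given here, the next entry is compound 3 (`CC(C)c1ccccc1-c1cccc(CNc2ccc(OCC(=O)O)c(F)c2)c1`), which has no measurement yet. Relative to compound 2, it carries isopropyl in place of fluoro on an aromatic carbon, ortho to a large group (isopropyl in place of fluoro on an aromatic carbon). Among the compounds with values here, no measured pair differs in one place only, so this change has no direct precedent here. Within the data shown here, the number of compound 1 (3.04) is the only reference above compound 2, and it gives a rough scale for the upper part of the range. In this assay an upward step is expected, estimated as a number 0.59 log units higher from compound 2 to compound 3 (beyond the scatter) and so beyond the scatter. For compound 3 the expected value is 2.95 and the estimated range runs from 2.55 to 3.35 for this measurement.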

Compound 3, distribution coefficient: 3.45
Estimate against measurement, compound 3: 0.50 log units below; measured number outside the range, above it.
By their numbers in this assay, from the lowest: compound 2; then compound 1; then compound 3.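

In this assay, the place on the six-membered aromatic ring of carbon only, ortho to a large group, now has its first step between compounds that differ in one place: with isopropyl in place of fluoro, the series shows a number 1.09 log units higher from compound 2 to compound 3 (beyond the scatter). The change is small by count, with 1 heavy atom of fluorine leaving and 3 heavy atoms of carbon entering, and neither group carries a ring, a hydrogen-bond donor, a hydrogen-bond acceptor or a net charge, yet the step is large, so this place is not indifferent to the exchange in this read-out. The data shown offer no measured basis for assigning a cause to the step.

A single pair leaves open how other groups at this place, such as an amine, a hydroxyl or a methyl group, would stand relative to fluoro and isopropyl. It also leaves open whether the same exchange gives a step of similar size on another core, since compound 1 differs from the other two compounds in more than one place and offers no such comparison.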